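The compounds below may be only part of what the source reports. "The series", "measured", "known", "first", "only" and "open" are said of these compounds alone.

In a functional assay on B16-F10 cells (Mus musculus) for antiproliferative activity, read by CCK-8 assay, with a stated time of 48 h (on this read-out higher numbers stand for weaker inhibition and lower numbers for stronger inhibition), compound 1 `COc1ccc(/C=C\c2cc(OC)c(OC)c(OC)c2)cc1OCc1ccc(CN2CCCC[C@@H]2C(=O)O)cc1` gives > 10000 nM, which is a limit of the assay. Compound 2 `COc1ccc(/C=C\c2cc(OC)c(OC)c(OC)c2)cc1OCc1ccc(CN2CC[C@@H](O)C2)cc1` gives > 10000 nM, also a limit and not a number. The series therefore stands at the limit of > 10000 nM in this assay, at which 2 of the 2 values shown sit, and compound 2 has no measured position beyond that limit.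

Compound 3 `COc1ccc(/C=C\c2cc(OC)c(OC)c(OC)c2)cc1OCc1ccc(CN2CCCCC2C(=O)NCCN)cc1` carries 2-((2-aminoethyl)carbamoyl)piperidin-1-yl in place of 3-hydroxypyrrolidin-1-yl on a saturated chain carbon bound to an aromatic carbon. Going by the values given here, the only measured step touching this place is a step that the two limits leave unreadable from compound 1 to compound 2, so it offers no size or direction to carry forward. No shift beyond the scatter is therefore expected in this assay, and another limit remains quite likely. The estimated step is a number no higher from compound 2 to compound 3 (the limit leaves the size open). For compound 3 the expected value is 10000 nM, with an estimated range of 3000 nM to 30000 nM.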

Compound 3, half-maximal inhibitory concentration: 4600 nM
Estimate against measurement, compound 3: 2.2-fold (0.34 log units) above, and the stated range covers the measured number.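

In this assay, the saturated chain carbon bound to an aromatic carbon gives its first readable change, with 2-((2-aminoethyl)carbamoyl)piperidin-1-yl in place of 3-hydroxypyrrolidin-1-yl producing an at least 2.1-fold lower number from compound 2 to compound 3 (0.33 log units; beyond the scatter) in the series. The same group in place of 2-carboxypiperidin-1-yl produces an at least 2.1-fold lower number from compound 1 to compound 3 (0.33 log units; beyond the scatter) at this position, so a six-membered non-aromatic ring with 1 hetero atom is not enough on its own to bring a compound off the limit, as compound 1 shows. Going by these compounds alone, compound 3 is the only compound here with a measured number, and the other two remain at a limit: the limit of > 10000 nM in this assay, at which 2 of the 3 values shown sit.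

The step between compound 1 and compound 2 cannot be read, and the two readable steps give only minimum sizes. On these data alone, it remains open whether the terminal primary amine or the amide carbonyl carries the change, and whether a longer chain or a tertiary amine at the chain end would move the number further.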